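A Swap of Aryl Groups on a Triazole Nitrogen

A few compounds are considered here, and "the series" means these few. Any claim that something is new, unique, unknown or untested is made for them only; others in the source may bear on it.

Among the compounds with values here, compound 3 `N#CC1=C(N)Oc2c(N)cc3nc4ccccc4nc3c2C12C(=O)N(Cc1cnnn1-c1cccc(C(F)(F)F)c1)c1ccccc12` is the only member of this small set with a numeric result: in a functional assay on HepG2 cells (Homo sapiens) for antiproliferative activity, read by MTT assay, with a stated time of 48 h (a lower number here means a stronger inhibitor, a higher number a weaker inhibitor), compound 3 gives 15800 nM. Compound 1 `CCOc1ccccc1-n1nncc1CN1C(=O)C2(C(C#N)=C(N)Oc3c2c2nc4ccccc4nc2c2ccccc32)c2ccccc21` returns only a limit of this assay, > 50000 nM. Compound 2 `N#CC1=C(N)Oc2c(c3nc4ccccc4nc3c3ccccc23)C12C(=O)N(Cc1cnnn1-c1ccc([N+](=O)[O-])cc1)c1ccccc12` likewise returns only a limit of this assay, > 50000 nM. Within the data shown here, the one measured step, a step that the two limits leave unreadable from compound 1 to compound 2, is therefore unreadable, and the limit of > 50000 nM in this assay, at which 2 of the 3 values shown sit, marks where both of those values sit. Compound 4 `N#CC1=C(N)Oc2c(N)cc3nc4ccccc4nc3c2C12C(=O)N(Cc1cnnn1-c1ccc(Cl)cc1[N+](=O)[O-])c1ccccc12` differs from compound 3 by 4-chloro-2-nitrophenyl in place of 3-(trifluoromethyl)phenyl on an aromatic nitrogen. Among the measured compounds shown here, no measured step touches this particular change, and the only step recorded on the same aromatic nitrogen has no readable size, so no direction can be drawn from the numbers in hand. In this assay the expected step is a 1.3-fold higher number from compound 3 to compound 4 (0.10 log units; within the scatter), small and carrying a wide spread. For compound 4 the estimate in this assay is 20000 nM, expected to fall between 6000 nM and 60000 nM.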

Compound 4, half-maximal inhibitory concentration: > 50000 nM
Compound 4: no number, only a limit (the forecaster's own chance of this, stated with the estimate: 30%); middle value at least 2.5-fold (0.39 log units) away from the limit.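

On this aromatic nitrogen, the change of aryl group now has a readable size in this assay, where the step from the earlier pair could not be read: 4-chloro-2-nitrophenyl in place of 3-(trifluoromethyl)phenyl gives an at least 3.1-fold higher number from compound 3 to compound 4 (0.50 log units; beyond the scatter). Compound 4 returns only a limit of this assay, > 50000 nM. The swap of this one aryl group is thus enough to move the shared core from a measurable number to the limit that now holds most of the set: the limit of > 50000 nM in this assay, at which 3 of the 4 values shown sit.

Left open is whether the chloro or the nitro part of the entering group carries the step. Also open, going by these compounds, is how a phenyl group bearing an amine or a carboxylic acid on this nitrogen would read, and whether any aryl group there gives a lower number than compound 3 at 15800 nM.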